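A few compounds are considered here, and "the series" means these few. Any claim that something is new, unique, unknown or untested is made for them only; others in the source may bear on it.

Of the compounds shown here, three have been measured in a functional assay on MCF-10A cells (Homo sapiens) for antiproliferative activity, with a stated time of 48 h; on this read-out higher numbers stand for an effect only at larger amounts of compound and lower numbers for an effect already at smaller amounts. Compound 1, `COc1cccc(CNc2cc(C)nc3ccc(OC)cc23)c1`, gives 12500 nM. Compound 3, `COc1ccc2nc(C)cc(NCc3cccc(CO)c3)c2c1`, gives 24700 nM; the change from compound 1 to compound 3 is hydroxymethyl in place of methoxy on an aromatic carbon, and it made a 2.0-fold higher number from compound 1 to compound 3 (0.30 log units; within the scatter). Compound 2, `COc1ccc2nc(C)cc(NCc3ccccc3OC)c2c1`, gives 29500 nM, a larger number than compound 1 and close to the number of compound 3. The difference between the core of compound 1 and the core of compound 2 is not broken down here.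

Compound 4, `COc1ccc2nc(C)cc(NCc3ccccc3CO)c2c1`, has not yet been measured in this assay. It differs from compound 2 by hydroxymethyl in place of methoxy on an aromatic carbon. For the measured compounds named here, this is the same kind of change as the one from compound 1 to compound 3, not the same change: in the earlier pair the group sits meta to a large group, while in compound 4 it sits ortho to a large group.

Because the earlier pair showed a 2.0-fold higher number from compound 1 to compound 3 (0.30 log units; within the scatter), the step from compound 2 to compound 4 is expected to be small, estimated at a 1.4-fold higher number from compound 2 to compound 4 (0.13 log units; within the scatter), with a number close to or somewhat larger than that of compound 2. On this basis compound 4 is estimated to give 40000 nM in this assay, expected to fall between 20000 nM and 90000 nM.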

Compound 4, half-maximal effective concentration: 25900 nM
Compound 4: middle estimate off by 1.5-fold (0.19 log units), on the high side; low and high end bracket the measured number.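

In this assay, hydroxymethyl in place of methoxy gives a 1.1-fold lower number from compound 2 to compound 4 (0.06 log units; within the scatter), a step too small to tell apart from the ordinary variation between repeated measurements. Set beside the earlier case, the same change on two cores gives steps that cannot be told apart, so in this small set it carries over from one core to the other as a change with no clear effect on the read-out: the same change on two cores in this assay, a 2.0-fold higher number (0.30 log units; within the scatter) from compound 1 to compound 3 and a 1.1-fold lower number (0.06 log units; within the scatter) from compound 2 to compound 4, 2.3-fold (0.35 log units) apart, within the scatter of two such steps. This does not show that the two steps are truly equal or that the change would behave the same way on any other core, since it rests on just two pairs, and those pairs differ in where the group sits on the ring.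

The compounds shown leave open whether a group of a different kind in the same place, such as an amine, a carboxylic acid or a longer chain ending in a hydroxyl, would move the number by more than the scatter. They also leave open whether hydroxymethyl in place of methoxy would stay this quiet on a core that lacks the methyl group these compounds share.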